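From Isopropyl to Cyclopentyl: Compound 3 and Compound 4

The source may report more compounds than this note shows. Statements on the series, on what has been measured and on what is new or still open speak of the compounds shown alone.

In an ADME assay on a cell-free system (plasma, Rattus norvegicus) for metabolic stability, read by LC-MS, with a stated time of 60 min, tested at 100 uM (a lower number here means that less of the compound is left, a higher number that more of the compound is left), three compounds have been measured so far. Compound 1 `Cc1c(OCCCCOCOc2ccc(C(=O)O)cc2)ccc(C(=O)CC2CCCC2)c1O` gives 100%, compound 2 `COc1ccc(C(=O)O)cc1OCCCCOc1ccc(C(=O)CC2CCCC2)c(O)c1C` gives 103%, and compound 3 `Cc1cc(OCCCCOc2ccc(C(=O)CC(C)C)c(O)c2C)ccc1C(=O)O` gives 101%. Compound 3 thus lies within the usual scatter of both others, and the three numbers cannot be told apart.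

Compound 4 `Cc1cc(OCCCCOc2ccc(C(=O)CC3CCCC3)c(O)c2C)ccc1C(=O)O` differs from compound 3 in one place: cyclopentyl in place of isopropyl on a saturated chain carbon bound to a carbonyl carbon.

Among the measured compounds shown here, the only measured step, a number 3 percentage points higher from compound 1 to compound 2 (within the scatter), lies within the scatter and concerns a different part of the structure, so it bears on this change only indirectly. For the measured compounds named here, no measured step makes this exact exchange. Still, compound 2 already carries cyclopentyl and gives 103%, so nothing points to a real shift. The expected step in this assay, a number 1 percentage points lower from compound 3 to compound 4 (within the scatter), is therefore none beyond the scatter. Compound 4 is estimated at 100%, with an expected range from 92% to 108%.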

Compound 4, percent of the compound remaining: 114%
Compound 4: the middle estimate sits 14 percentage points below what was measured; measured number above the stated range.
By their numbers in this assay, from the lowest: compounds 1, 3 and 2 (each within the scatter of the next); then compound 4.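

In this assay, among the compounds shown here, cyclopentyl in place of isopropyl on a saturated chain carbon bound to a carbonyl carbon gives a number 13 percentage points higher from compound 3 to compound 4 (beyond the scatter) and so moves the read-out beyond the scatter, which no step among the earlier compounds did. Cyclopentyl alone does not settle the number: compound 1 and compound 2 carry it too, yet 4-carboxy-3-methylphenyl on the oxygen gives a number 11 percentage points higher from compound 2 to compound 4 (beyond the scatter) when it replaces 5-carboxy-2-methoxyphenyl and a number 14 percentage points higher from compound 1 to compound 4 (beyond the scatter) when it replaces (4-carboxyphenoxy)methyl. Nothing available explains why these numbers differ.

From the compounds shown here alone, this exchange rests on a single pair of compounds, so it remains open whether cyclohexyl or a longer chain at this place would behave like cyclopentyl. Going by these compounds, it is equally open whether an amine there would leave the number where compound 3 stands.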